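Acetoxy to Benzoyloxy on a Shared Core

The source may hold more compounds than are shown below. What is called first, only, known or untested is meant among the compounds shown, and "the series" means these compounds.

In a functional assay on Ishikawa cells (Homo sapiens) for inhibition, read by MTT assay, with a stated time of 72 h, tested at 30 ug/mL (a higher number here means more inhibition of growth at the concentration tested, a lower number less inhibition of growth), compound 1 (`C=C1[C@H](OCC(C)C)C[C@@H](OC(=O)c2cccnc2)C(C)(C)/C=C/[C@@H](C)C(=O)[C@@]2(OC(C)=O)C[C@@](C)(OC(C)=O)[C@H](OC(C)=O)[C@@H]2[C@H]1OC(C)=O`) gives 26.6% and compound 2 (`C=C1[C@H](OC(C)=O)CC(=O)C(C)(C)/C=C/[C@@H](C)C(=O)[C@@]2(OC(C)=O)C[C@@](C)(OC(C)=O)[C@H](OC(C)=O)[C@@H]2[C@H]1OC(C)=O`) gives 35% and these two values lie within the scatter of each other. Compound 3 (`C=C1[C@H](OC(C)=O)CC(=O)C(C)(C)/C=C/[C@@H](C)C(=O)[C@@]2(OC(C)=O)C[C@@](C)(OC(=O)c3ccccc3)[C@H](OC(C)=O)[C@@H]2[C@H]1OC(C)=O`) differs from compound 2 by phenyl in place of methyl on a carbonyl carbon in the form of phenyl in place of methyl on a carbonyl carbon, or acetoxy to benzoyloxy. Among the compounds with values here, no measured pair shows this change, and no step beyond the scatter is expected in this assay in either direction. The estimated move is a number 2 percentage points higher from compound 2 to compound 3 (within the scatter) and stays inside that scatter. For compound 3 the expected value is 37% with an estimated range from 20% to 56% at the single concentration tested.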

Compound 3, percent growth inhibition at one concentration: 29.4%
Estimate against measurement, compound 3: 7.6 percentage points above; low and high end bracket the measured number.
By their numbers in this assay, from the lowest: compounds 1, 3 and 2 (each within the scatter of the next).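

Within the data shown here, the step of a number 5.6 percentage points lower from compound 2 to compound 3 (within the scatter) in this assay is the first reading of this change: phenyl in place of methyl on a carbonyl carbon, which brings in one six-membered aromatic ring, leaves the two compounds within the scatter of each other. A single pair cannot show a trend at this position. Nothing here offers an explanation for this result.

As far as these compounds go, it remains open whether a longer chain or an amine on this carbonyl carbon would give a step beyond the scatter. From the compounds shown here alone, it is also open whether acetoxy to benzoyloxy would read the same on another core.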